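Cutting the Butyl Chain Down to Methyl

This account rests on a few compounds, and the source may have more. Where it says the series, first, only, none or still open, it means among the compounds named here.

Compound 1 (`CCCCc1ccc2[nH]c(-c3ccc(OC)cc3)c(/C=N/NC(=O)c3ccccc3OC)c2c1`) and compound 2 (`CCCCc1ccc2[nH]c(-c3ccc(OC)cc3)c(/C=N/NC(=O)c3ccncc3)c2c1`) are tested in a functional assay on MCF7 cells (Homo sapiens) for antiproliferative activity, with a stated time of 5 days; a higher number here means a weaker inhibitor, a lower number a stronger inhibitor. There, compound 1 gives 71 nM and compound 2 gives 69 nM. The two stand level, with a 1.0-fold lower number from compound 1 to compound 2 (0.01 log units; within the scatter), so compound 2 offers a good starting number but no clear lead over its neighbour.

Compound 3 (`COc1ccc(-c2[nH]c3ccc(C)cc3c2/C=N/NC(=O)c2ccncc2)cc1`) keeps the pyridin-4-yl of compound 2 and alters the other end of the story, the butyl chain: hydrogen in place of propyl on a saturated chain carbon bound to an aromatic carbon. In words, this is hydrogen in place of propyl on a saturated chain carbon bound to an aromatic carbon, so butyl becomes methyl.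

For the measured compounds named here, the only measured step, a 1.0-fold lower number from compound 1 to compound 2 (0.01 log units; within the scatter), is a change on a carbonyl carbon, not on this chain. Going by the values given here, it therefore gives no direct guide, and no measured pair yet varies the chain. Since much of the chain goes, a move to a higher number in this assay, meaning a weaker inhibitor, is expected, though its size is uncertain. The step is estimated to be a 2.2-fold higher number from compound 2 to compound 3 (0.34 log units; beyond the scatter).

Compound 3 is estimated at 150 nM, with an expected range of 40 nM to 600 nM.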

Compound 3, half-maximal inhibitory concentration: 200 nM
Compound 3: middle estimate off by 1.3-fold (0.12 log units), on the low side, and the stated range covers the measured number.
By their numbers in this assay, from the lowest: compounds 2 and 1 (each within the scatter of the next); then compound 3.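

For the compounds shown here, until now, the only measured change sat on a carbonyl carbon and left the number within the scatter, whereas shortening butyl to methyl in this assay gives a 2.9-fold higher number from compound 2 to compound 3 (0.46 log units; beyond the scatter), a modest step but one beyond the scatter. This makes the chain the first place in this small set where a single change clearly separates two compounds, and the direction is toward a weaker inhibitor. The part that leaves is a propyl group made of carbon alone, with no ring, no hydrogen-bond donors or acceptors and no net charge, so in this pair a change of that plain kind is enough to shift the number, although nothing measured here accounts for the shift.

With only butyl and methyl to compare, the compounds shown cannot tell whether the number changes gradually with chain length, or whether ethyl, a longer chain such as hexyl, or a ring such as cyclohexyl would match butyl or improve on it. From the compounds shown here alone, it also remains open whether the same shortening would have a similar effect with 2-methoxyphenyl on the carbonyl carbon in place of pyridin-4-yl.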